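Cytotoxicity on mouse fibroblasts: 2-aminobenzyl to 3-cyanobenzyl

The compounds below may be only part of what the source reports. "The series", "measured", "known", "first", "only" and "open" are said of these compounds alone.

Three compounds of the series have a result in a toxicity assay on NIH3T3 cells (Mus musculus) for cytotoxicity, read by resazurin assay; a lower number here means that less compound is needed, a higher number that more compound is needed for the effect. Compound 1 `COC(=O)c1ccc(NCc2cncn2Cc2ccccc2N)cc1-c1ccccc1` gives 25000 nM in this assay, the highest of the two numbers recorded. The nearest number belongs to compound 3 `Clc1ccc(Cn2cncc2CNc2cccc(-c3ccccc3)c2)cc1`, which gives 10000 nM in this assay, a gap that lies beyond the usual scatter. Compound 2 `Cc1ccccc1-c1cc(NCc2cncn2Cc2ccc(-c3ccccc3)cc2)ccc1-c1nc2ccccc2s1` gives only a limit of the assay, > 1000 nM, so no number is known for it. This is the limit of > 1000 nM in this assay, at which 1 of the 3 values shown sits. Going by the values given here, no pair of measured compounds differs in a single place, so no measured step is available for guidance.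

Compound 4 `COC(=O)c1ccc(NCc2cncn2Cc2cccc(C#N)c2)cc1-c1ccccc1` is not yet measured. It differs from compound 1 in one place: 3-cyanophenyl in place of 2-aminophenyl on a saturated chain carbon bound to an aromatic nitrogen. The shared core and the remainder of compound 1 are kept. With no measured step of this kind in the series, only a small step is expected, within or near the scatter and with no strong direction: a 1.3-fold lower number from compound 1 to compound 4 (0.10 log units; within the scatter). Compound 4 is accordingly estimated at 20000 nM in this assay, with a range from 7000 nM to 50000 nM, and a fair chance that the assay again reports only a limit.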

Compound 4, half-maximal effective concentration: > 10000 nM
Compound 4: no number, only a limit (the forecaster's own chance of this, stated with the estimate: 25%); the middle value is on the limit's open side.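

In this assay, going by these compounds alone, compound 4 gives > 10000 nM, which is a limit of the assay and not a number, so no step from compound 1 to compound 4 can be read. The compounds shown leave open whether 3-cyanobenzyl in place of 2-aminobenzyl shifts the number in this assay at all, and in which direction.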